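From Allyloxy to 2-Hydroxyethoxy at the Assay Limit

The source may report more compounds than this note shows. Statements on the series, on what has been measured and on what is new or still open speak of the compounds shown alone.

In a functional assay on A-375 cells (Homo sapiens) for cytotoxicity, read by MTT assay (a higher number here means a weaker inhibitor, a lower number a stronger inhibitor), compound 1 `C#CCOc1cc(/C=C/C(=O)c2ccc(OC)c3c2OC(C)(C)C=C3)ccc1OC` reaches only the limit > 10000 nM and gives no number. Compound 2 `C=CCOc1cc(/C=C/C(=O)c2ccc(OC)c3c2OC(C)(C)C=C3)ccc1OC` likewise stands at the limit > 10000 nM with no number behind it. The picture so far is the limit of > 10000 nM in this assay, at which 2 of the 2 values shown sit, and nothing more. Within the data shown here, this leaves a step that the two limits leave unreadable from compound 1 to compound 2 as the only measured step, and it offers no size to carry forward. Compound 3 `COc1ccc(/C=C/C(=O)c2ccc(OC)c3c2OC(C)(C)C=C3)cc1OCCO` differs from compound 2 at one end of the side chain: hydroxymethyl in place of vinyl on a saturated chain carbon bound to an oxygen on an aromatic ring; in short, allyloxy becomes 2-hydroxyethoxy. With no readable step to lean on, no change beyond the scatter is expected in this assay for this swap, and another limit is the likeliest report. The expected change is a step that the limit leaves unreadable from compound 2 to compound 3 and it remains only an estimate. Compound 3 is estimated at 15000 nM with an expected range from 5000 nM to 50000 nM in this measurement.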

Compound 3, half-maximal inhibitory concentration: 9600 nM
Compound 3: middle estimate off by 1.6-fold (0.19 log units), on the high side; the measured number falls inside the stated range.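

In this assay, among these compounds, compound 3 gives 9600 nM, the first actual number for this side chain. Set against the limits of the two other compounds, the data give an at least 1.0-fold lower number from compound 2 to compound 3 (0.01 log units; that floor lies within the scatter) and an at least 1.0-fold lower number from compound 1 to compound 3 (0.01 log units; that floor lies within the scatter), so each swap to hydroxymethyl can be read only as a floor, and the true size of either step remains unknown. The set as a whole still sits at the edge of what the assay can read: the limit of > 10000 nM in this assay, at which 2 of the 3 values shown sit.

As far as these compounds go, it remains open whether an amine, a carboxylic acid or a longer chain ending in hydroxyl, put in place of hydroxymethyl, would give a step clearly beyond the scatter. The step between the two compounds at the limit also stays unreadable, so vinyl and ethynyl cannot be ranked against each other.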